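Dropping the 4-chloro from the dichlorophenyl amide of compound 1

This account rests on a few compounds, and the source may have more. Where it says the series, first, only, none or still open, it means among the compounds named here.

Three compounds on the shared core have numbers in an assay on HEK293 cells for inhibition of melanin-concentrating hormone receptor 1 (Homo sapiens), read by radioligand binding; on this read-out higher numbers stand for weaker inhibition and lower numbers for stronger inhibition. Compound 1, `CN(C)c1nc(N[C@H]2CC[C@@H](NC(=O)c3ccc(Cl)c(Cl)c3)CC2)nc2ccccc12`, gives 5 nM and stands at the lowest number of the three, with both others beyond the scatter from it. Compound 3, `CN(C)c1nc(N[C@H]2CC[C@@H](NS(=O)(=O)c3ccc(Br)cc3OC(F)(F)F)CC2)nc2ccccc12`, carries a sulfonamide in place of the amide and gives 83 nM. Compound 2, `CN(C)c1nc(NCC2CCC(CNC(=O)c3ccc(Br)cc3OC(F)(F)F)CC2)nc2ccccc12`, with methylene spacers on both sides of the cyclohexane and a different aryl group, gives 1500 nM. Going by the values given here, no pair of these differs in only one place, so no single step is isolated among the measured compounds.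

Compound 4, `CN(C)c1nc(N[C@H]2CC[C@@H](NC(=O)c3cccc(Cl)c3)CC2)nc2ccccc12`, differs from compound 1 by hydrogen in place of chloro on an aromatic carbon. The change cut one bond further out reads 3,4-dichlorophenyl to 3-chlorophenyl.

Nothing measured here separates the contribution of the chloro that leaves; the expectation rests on compound 1 alone at 5 nM. A moderate rise in the number for compound 4 is expected in this assay, beyond the scatter but well short of the gap to compound 3. The step from compound 1 to compound 4 is estimated at a 4.0-fold higher number from compound 1 to compound 4 (0.60 log units; beyond the scatter). Compound 4 is therefore estimated at 20 nM, with a range from 6 nM to 70 nM.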

Compound 4, half-maximal inhibitory concentration: 4.5 nM
For compound 4 the middle estimate is 4.4-fold (0.65 log units) above the measured one; measured number outside the range, below it.
By their numbers in this assay, from the lowest: compounds 4 and 1 (each within the scatter of the next); then compound 3; then compound 2.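

Going by these compounds alone, this is the first step that changes one place only. In this assay it reads a 1.1-fold lower number from compound 1 to compound 4 (0.05 log units; within the scatter), so the chloro on the aromatic carbon para to a large group can give way to hydrogen with the two numbers staying within the scatter of each other. On this amide and this core, then, the 3-chlorophenyl group of compound 4 reads the same as the 3,4-dichlorophenyl group of compound 1, and the second chloro is not needed to hold the number in this range, a finding that rests on this single pair. No measurement of any other kind accompanies this step, so the data offer no account of it.

Still open, on these data alone, is what happens when the remaining chloro also gives way to hydrogen, leaving a plain phenyl amide, or when the carbon para to a large group carries a methoxy group or an amine instead of chloro or hydrogen. The gaps to compound 2 and compound 3 also stay unassigned, as each of these differs from compound 1 and compound 4 in more than one place.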